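This account rests on a few compounds, and the source may have more. Where it says the series, first, only, none or still open, it means among the compounds named here.

Compound 1, `Cc1ccsc1C(=O)/C=C/c1ccc(N2CCCCC2)cc1`, in an ADME assay on CCRF-CEM cells (Homo sapiens) for cytotoxicity, with a stated time of 5 days (a higher number here means a weaker inhibitor, a lower number a stronger inhibitor), gives 9900 nM. Compound 2, `c1csc(C2=NNC(c3ccc(N4CCCCC4)cc3)C2)c1`, shares the piperidine-bearing phenyl ring but carries it on a different core; in this assay compound 2 gives 6900 nM, a number that sits within the usual scatter of the number for compound 1, so the two cannot be told apart. Compound 3, `Clc1ccc(C2=NNC(c3ccc(N4CCCCC4)cc3)C2)s1`, differs from compound 2 by one change: chloro in place of hydrogen on an aromatic carbon. Among the compounds with values here, no measured pair shows what such a change does here, so the expected step from compound 2 to compound 3 is a 1.4-fold lower number from compound 2 to compound 3 (0.14 log units; within the scatter), likely small and not clearly beyond the scatter. Compound 3 is therefore estimated at 5000 nM, within a range from 1500 nM to 15000 nM.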

Compound 3, half-maximal inhibitory concentration: > 100000 nM
Compound 3 ended at the assay's limit; the forecaster's own chance of this, stated with the estimate: 5%; at least 20-fold (1.30 log units) between middle value and limit.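

Swapping thiophen-2-yl for 5-chlorothiophen-2-yl gives an at least 14-fold higher number from compound 2 to compound 3 (1.16 log units; beyond the scatter) in this assay. This position, next to the ring sulfur, is therefore sensitive to even a small change: one chlorine atom in place of hydrogen is enough to weaken the compound sharply. The value for compound 3 is a limit of the assay, not a number: the limit of > 100000 nM in this assay, at which 1 of the 3 values shown sits.

The compounds shown leave open whether this loss is specific to chloro or would follow any group on this carbon. A fluoro, a methyl or an amine at the same place would tell these apart.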